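The source may report more compounds than this note shows. Statements on the series, on what has been measured and on what is new or still open speak of the compounds shown alone.

Of the compounds shown here, two from this study have been tested in a toxicity assay on RMS13 cells (Homo sapiens) for inhibition, with a stated time of 24 h; on this read-out higher numbers stand for weaker inhibition of growth and lower numbers for stronger inhibition of growth. Compound 1 `CC1=C(C(=O)OCc2ccccc2)C(c2ccc(-c3ccccc3C)cc2)NC(=O)N1Cc1ccc(-c2nnn[nH]2)cc1` gives 73000 nM in this assay. Compound 2 `CC1=C(C(=O)OCc2ccccc2)C(c2ccc(-c3ccccc3)cc2)N(CCCCCC(=O)O)C(=S)N1` gives 110000 nM in this assay. Compound 1 carries the lower of these two numbers, but its gap to compound 2 lies within the usual scatter of repeated measurements, so the two cannot be told apart on what has been measured; both inhibit growth only weakly on this read-out.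

Compound 3 `CC1=C(C(=O)OCc2ccccc2)C(c2ccc(-c3ccccc3C)cc2)NC(=O)N1CCCCCc1nnn[nH]1` has not yet been measured in this assay. It differs from compound 1 in one place: 4-(1H-tetrazol-5-yl)butyl in place of 4-(1H-tetrazol-5-yl)phenyl on a saturated chain carbon bound to an amide-type nitrogen in a ring. The rest of the shared core is kept. Within the data shown here, no pair of measured compounds shows what such a change does to growth inhibition here, so the size of the step cannot be read from the data. Compound 1 gives 73000 nM, and the change is confined to one substituent, so a step within the scatter, in either direction, is expected. Compound 3 is therefore estimated at 80000 nM, with a likely range from 30000 nM to 200000 nM. This estimate amounts to an expected step of a 1.1-fold higher number from compound 1 to compound 3 (0.04 log units; within the scatter).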

Compound 3, concentration for 50% growth inhibition: 100000 nM
Compound 3: the middle estimate sits 1.3-fold (0.10 log units) below what was measured, within the range that was stated.
By their numbers in this assay, from the lowest: compounds 1, 3 and 2 (each within the scatter of the next).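

In this assay, putting 4-(1H-tetrazol-5-yl)butyl in place of 4-(1H-tetrazol-5-yl)phenyl, on a saturated chain carbon bound to an amide-type nitrogen in a ring, gives a 1.4-fold higher number from compound 1 to compound 3 (0.14 log units; within the scatter). Among these compounds, this is the first direct comparison at this position: the six-membered aromatic ring of carbon is exchanged for a saturated chain while the tetrazole and the rest of the shared core stay in place, and the two compounds cannot be told apart on this read-out. No measurement of any property of these compounds bears on this result, so it offers no explanation for it.

The compounds shown leave open whether the tetrazole itself matters at this position, which an amine in its place on the same butyl chain could test, and whether a chain longer than butyl would give a step beyond the scatter. From the compounds shown here alone, since this single exchange produced no clear step, it also remains unknown whether any other substituent here could turn this weak growth inhibition into a clearly stronger one.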